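Compound 3 to compound 4: methylsulfanyl replaces carboxy

The source may hold more compounds than are shown below. What is called first, only, known or untested is meant among the compounds shown, and "the series" means these compounds.

In a functional assay (aorta) with Rattus norvegicus as the target (a higher number here means a weaker inhibitor, a lower number a stronger inhibitor), compound 1 `CC1(C)Oc2ccc(C#N)cc2[C@@H](/N=C(\NC#N)Nc2ccc(N)cc2)[C@@H]1O` gives 3500 nM and compound 2 `CC1(C)Oc2ccc(C#N)cc2[C@@H](/N=C(\NC#N)Nc2ccc([N+](=O)[O-])cc2)[C@@H]1O` gives 300 nM. Compound 3 `CC1(C)Oc2ccc(C#N)cc2[C@@H](/N=C(\NC#N)Nc2cccc(C(=O)O)c2)[C@@H]1O` gives > 100000 nM, which is a limit and not a number. Compound 4 `CSc1cccc(N/C(=N/[C@@H]2c3cc(C#N)ccc3OC(C)(C)[C@H]2O)NC#N)c1` has methylsulfanyl in place of carboxy on an aromatic carbon, meta to a large group (methylsulfanyl in place of carboxy on an aromatic carbon). This exact change is unmeasured, but two steps lead to the carboxy compound: an at least 28-fold higher number from compound 1 to compound 3 (1.45 log units; beyond the scatter) and an at least 330-fold higher number from compound 2 to compound 3 (2.52 log units; beyond the scatter). Both are large, while a 12-fold lower number from compound 1 to compound 2 (1.07 log units; beyond the scatter) shows the spread between the two compounds without carboxy. A large step to a lower number is therefore expected in this assay, estimated as an at least 110-fold lower number from compound 3 to compound 4 (2.04 log units; beyond the scatter). Compound 4 is estimated at 900 nM, with an expected range of 150 nM to 5000 nM.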

Compound 4, half-maximal inhibitory concentration: 1400 nM
Estimate against measurement, compound 4: 1.6-fold (0.19 log units) below; the measured number falls inside the stated range.
By their numbers in this assay, from the lowest: compound 2; then compound 4; then compound 1. At a limit, above all of these: compound 3.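

With methylsulfanyl on this aromatic carbon, meta to a large group, a number returns in this assay: an at least 71-fold lower number from compound 3 to compound 4 (1.85 log units; beyond the scatter). The value of compound 3 is a limit and not a number: the limit of > 100000 nM in this assay, at which 1 of the 4 values shown sits. A group at this position therefore still allows inhibition, and the result sits among the para-free comparisons as a 2.5-fold lower number from compound 1 to compound 4 (0.40 log units; beyond the scatter) and a 4.7-fold higher number from compound 2 to compound 4 (0.67 log units; beyond the scatter).

No group appears here at both ring positions, so the effect of the group and the effect of its place remain unseparated. An amine or a nitro group on the carbon holding methylsulfanyl would separate them.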